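The source may hold more compounds than are shown below. What is called first, only, known or untested is meant among the compounds shown, and "the series" means these compounds.

In a functional assay on the whole organism for inhibition, with Canis familiaris (Canis lupus familiaris) as the target (on this read-out higher numbers stand for an effect only at larger amounts of compound and lower numbers for an effect already at smaller amounts), compound 2 `CCN1CCCC1CNC(=O)c1cc(NS(C)(=O)=O)c(C)cc1OC` gives 1 mg/kg, and compound 1 `CCN1CCCC1CNC(=O)c1cc(N(C)S(C)(=O)=O)c(C)cc1OC` gives 1 mg/kg. Among the compounds with values here, the single change between them, (methyl in place of hydrogen on a sulfonamide nitrogen), produced a step of no change at the digits printed from compound 2 to compound 1 (within the scatter). Compound 3 `CCN1CCCC1CNC(=O)c1cc(NS(N)(=O)=O)ccc1OC` is built on a different core; the difference between the two cores is not broken down here. In this assay compound 3 gives 10 mg/kg, the highest of the three numbers, with a gap beyond the usual scatter to compound 1 and to compound 2. Compound 4 `CCN1CCCC1CNC(=O)c1cc(N(C)S(N)(=O)=O)ccc1OC` differs from compound 3 by methyl in place of hydrogen on a sulfonamide nitrogen, the same change at the same place as from compound 2 to compound 1. On the strength of no change at the digits printed from compound 2 to compound 1 (within the scatter), the step expected is no change at the digits printed from compound 3 to compound 4 (within the scatter). In this assay compound 4 is therefore estimated at 10 mg/kg, likely between 4 mg/kg and 25 mg/kg.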

Compound 4, dose for half-maximal effect: 1 mg/kg
Compound 4: middle estimate off by 10-fold (1.00 log units), on the high side; measured number outside the range, below it.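

In this assay, methyl in place of hydrogen on the sulfonamide nitrogen gives a 10-fold lower number from compound 3 to compound 4 (1.00 log units; beyond the scatter), so the result of this change on one core did not carry over to the other: the same change on two cores in this assay, no change at the digits printed (within the scatter) from compound 2 to compound 1 and a 10-fold lower number (1.00 log units; beyond the scatter) from compound 3 to compound 4, 10-fold (1.00 log units) apart, beyond the scatter of two such steps The size of the step therefore depends on the core in these two pairs, so a step measured on one of these cores is a poor guide to the other. The two cores differ in more than one place, however, so these pairs do not show which difference matters, and two pairs set no rule for the whole series.

Going by these compounds, it remains open whether a propyl group on that sulfonamide nitrogen would follow the methyl on either core. On these data alone, it is also open how the methyl change would behave on a third core.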